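This account rests on a few compounds, and the source may have more. Where it says the series, first, only, none or still open, it means among the compounds named here.

Within the data shown here, compound 1 `CC(C)(C)Sc1c(CC(C)(C)C(=O)O)n(Cc2ccc(Cl)cc2)c2ccc(OCc3ccc4cccnc4n3)cc12` gives 6 nM in a functional assay for inhibition, with Homo sapiens as the target (a higher number here means a weaker inhibitor, a lower number a stronger inhibitor), and the only other measured compound, compound 2 `CC(C)(C)Sc1c(CC(C)(C)C(=O)O)n(Cc2ccc(Cl)cc2)c2ccc(OCc3cccnc3)cc12`, gives 8 nM, so compound 1 sits within the scatter of the one comparison available. Among the measured compounds shown here, the step of a 1.3-fold higher number from compound 1 to compound 2 (0.12 log units; within the scatter) is the only one bearing on compound 3 `CC(C)(C)Sc1c(CC(C)(C)C(=O)O)n(Cc2ccc(Cl)cc2)c2ccc(OCc3cccs3)cc12`, which differs from compound 1 by a group of 5 heavy atoms (4 carbon, 1 sulfur; one five-membered aromatic ring with 1 hetero atom) in place of a group of 10 heavy atoms (8 carbon, 2 nitrogen; 2 six-membered aromatic rings with 1 hetero atom each), on a saturated chain carbon bound to an oxygen on an aromatic ring. Since the related exchange in this assay produced no shift beyond the scatter, the step of a 1.7-fold higher number from compound 1 to compound 3 (0.22 log units; within the scatter) is expected to be small and direction is not inferable. Compound 3 is therefore estimated at 10 nM in this assay, with a range of 4 nM to 30 nM.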

Compound 3, half-maximal inhibitory concentration: 4 nM
Estimate against measurement, compound 3: 2.5-fold (0.40 log units) above; the measured number falls inside the stated range.
By their numbers in this assay, from the lowest: compounds 3, 1 and 2 (each within the scatter of the next).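

Thiophen-2-yl on a saturated chain carbon bound to an oxygen on an aromatic ring keeps the value in the same range in this assay: a 1.5-fold lower number from compound 1 to compound 3 (0.18 log units; within the scatter), and a 2.0-fold lower number from compound 2 to compound 3 (0.30 log units; within the scatter), both within the scatter. A ring nitrogen in this group is therefore not required for a value in this range, and neither is the larger group of compound 1. Nothing available accounts for these steps.

As far as these compounds go, whether an aromatic ring is needed here at all remains open, and a cyclohexyl group would address that. Also open, from the compounds shown here alone, is how an amine or a carboxylic acid on this ring would read.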